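The source may report more compounds than this note shows. Statements on the series, on what has been measured and on what is new or still open speak of the compounds shown alone.

Compound 1 `Cc1oc(-c2ccc(Cl)cc2)nc1CN1CCC(C(=O)NCCCN2C[C@H](C)C[C@H](C)C2)CC1` was examined in a physicochemical assay for solubility, in phosphate buffer, measured as kinetic solubility, at pH 7.4; on this read-out higher numbers stand for higher solubility and lower numbers for lower solubility. In this assay compound 1 gives > 72 ug/mL, which is a limit of the assay rather than a number. Compound 2 `Cc1ccccc1-c1nc(CN2CCC(C(=O)NCCCN3CCC(C)CC3)CC2)c(C)o1` gives > 67 ug/mL, again a limit rather than a number. Both measured values therefore sit at limits, at the limit of > 72 ug/mL in this assay, at which 1 of the 2 values shown sits, and at the limit of > 67 ug/mL in this assay, at which 1 of the 2 values shown sits. Compound 3 `COc1cccc(Cl)c1-c1nc(CN2CCC(C(=O)NCCCN3C[C@H](C)C[C@H](C)C3)CC2)c(C)o1` is not yet measured; it differs from compound 1 by 2-chloro-6-methoxyphenyl in place of 4-chlorophenyl on an aromatic carbon. No step beyond the scatter is expected from compound 1 to compound 3, an at least 1.0-fold lower number from compound 1 to compound 3 (0.01 log units; that floor lies within the scatter). Compound 3 is estimated at 70 ug/mL, most likely between 30 ug/mL and 120 ug/mL.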

Compound 3, solubility: > 76 ug/mL
Compound 3 gave a limit, no number; the forecaster's own chance of this, stated with the estimate: 65%; middle value at least 1.0-fold (0.03 log units) from the limit.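

In this assay compound 1 and compound 3 both give limits rather than numbers, so no step can be read between them. From the compounds shown here alone, whether 2-chloro-6-methoxyphenyl in place of 4-chlorophenyl changes the read-out at all stays open.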